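A few compounds are considered here, and "the series" means these few. Any claim that something is new, unique, unknown or untested is made for them only; others in the source may bear on it.

Three members of one series have been run through an in vitro ADME assay on microsomes from liver (Homo sapiens) for metabolic stability; a higher number here means that the compound lasts longer, a lower number that the compound disappears faster. Compound 1 `CS(=O)(=O)Nc1ccc2c(c1)S(=O)(=O)N=C(C1=C(O)C3CCCC3N(Cc3ccccn3)C1=O)N2` reaches the limit of the measurement, giving > 1 h. Compound 2 `CS(=O)(=O)Nc1ccc2c(c1)S(=O)(=O)N=C(C1=C(O)C3CCCCC3N(Cc3ccc(F)cc3)C1=O)N2` likewise stops at the limit, with > 1 h. Compound 3 `CS(=O)(=O)Nc1ccc2c(c1)S(=O)(=O)N=C(C1=C(O)[C@H]3CCC[C@H]3N(Cc3ccc(C(F)(F)F)cc3)C1=O)N2` also returns only the limit, > 1 h, so it cannot be ranked against the others, as the limit of > 1 h in this assay, at which 3 of the 3 values shown sit, shows. Compound 4 `CS(=O)(=O)Nc1ccc2c(c1)S(=O)(=O)N=C(C1=C(O)[C@H]3CCC[C@H]3N(Cc3cccc(C(F)(F)F)c3)C1=O)N2` has not been measured yet; it carries 3-(trifluoromethyl)phenyl in place of 4-(trifluoromethyl)phenyl on a saturated chain carbon bound to an amide-type nitrogen in a ring. Among the compounds with values here, no step between measured compounds is available, so the size of this change cannot be read from the data. Compound 4 is expected to sit at the limit as well, with an estimated step that the limit leaves unreadable from compound 3 to compound 4 lying within the scatter. The estimate for compound 4 in this assay is 1.5 h, ranging from 0.7 h to 3 h.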

Compound 4, half-life: > 1 h
Compound 4 was reported as a limit (the forecaster's own chance of this, stated with the estimate: 75%); the middle value is on the limit's open side.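

No step from compound 3 to compound 4 can be read, since both stand only as limits in this assay: the limit of > 1 h in this assay, at which 4 of the 4 values shown sit.

The compounds shown leave open how long any of them actually lasts, and whether 3-(trifluoromethyl)phenyl and 4-(trifluoromethyl)phenyl differ at all.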